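Primary amide in place of the 2-aminophenyl amide

This account rests on a few compounds, and the source may have more. Where it says the series, first, only, none or still open, it means among the compounds named here.

Two compounds of the series have numbers in an assay on Sf9 cells for inhibition of protein deacetylase HDAC6 (Homo sapiens), read by fluorescence, with a stated time of 40 min, tested at 100 nM; a lower number here means less inhibition, a higher number more inhibition at the concentration tested (going by the name of the read-out). Compound 1 `O=C(NO)c1ccc(NCc2nc(-c3ccc(Br)o3)nn2-c2ccccc2)cc1` gives 55.8%. Compound 2 `Nc1ccccc1NC(=O)c1ccc(NCc2nc(-c3ccccc3)nn2-c2ccccc2)cc1` gives 5%, the lowest of the two values, with the gap to compound 1 beyond the scatter. Compound 3 `NC(=O)c1ccc(NCc2nc(-c3ccccc3)nn2-c2ccccc2)cc1` has not been measured. From compound 2 to compound 3 the change is hydrogen in place of 2-aminophenyl on an amide-type nitrogen. Going by the values given here, no measured pair shows this step, so its size is unknown; given compound 2 at 5%, little room remains below it, and the step from compound 2 to compound 3 is expected to stay within the scatter, at a number 2 percentage points lower from compound 2 to compound 3 (within the scatter). Compound 3 is expected to read 3%, within -5% to 15%.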

Compound 3, a percentage reported as inhibition, at one concentration (the size of the read-out at that concentration, not a potency): -4.4%
For compound 3 the middle estimate is 7.4 percentage points above the measured one; measured number inside the range.
By their numbers in this assay, from the lowest: compounds 3 and 2 (each within the scatter of the next); then compound 1.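

In this assay the change of hydrogen in place of 2-aminophenyl on an amide-type nitrogen gives a number 9.4 percentage points lower from compound 2 to compound 3 (within the scatter) and so does not separate the primary amide from the 2-aminophenyl amide. Going by these compounds alone, this is the first reading at this position: the whole 2-aminophenyl group can go without a shift that stands clear of the scatter, so on this core neither amide form gives a readable signal.

What a carboxylic acid, or a methyl on the amide-type nitrogen, would read on the core of compound 3 stays open, and nothing measured here accounts for the result.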